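The source may report more compounds than this note shows. Statements on the series, on what has been measured and on what is new or still open speak of the compounds shown alone.

Compound 1 `COc1ccc(CNC(=O)c2nc(-c3ccc(F)cc3)n(CC[C@@H](O)C[C@@H](O)CC(=O)O)c2C2CC2)cc1F` gives 3.7 nM in an assay on microsomes from liver for inhibition of 3-hydroxy-3-methylglutaryl-coenzyme A reductase (Rattus norvegicus), read by scintillation counting, with stated times of 0.5 h and 0.75 h; a higher number here means a weaker inhibitor, a lower number a stronger inhibitor.
Compound 2 `Cc1ccc(CNC(=O)c2nc(-c3ccc(F)cc3)n(CC[C@@H](O)C[C@@H](O)CC(=O)O)c2C2CC2)cc1` gives 1.7 nM in this assay.
Compound 3 `CCc1c(C(=O)NCc2ccccc2)nc(-c2ccc(F)cc2)n1CC[C@@H](O)C[C@@H](O)CC(=O)O` gives 123 nM in this assay.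

Compound 2 has the lowest number of the three; the nearest is compound 1, and the furthest is compound 3, whose value is well beyond the scatter from it. The unmeasured compound 4 `O=C(O)C[C@H](O)C[C@H](O)CCn1c(-c2ccc(F)cc2)nc(C(=O)NCc2ccccc2)c1C1CC1` differs from compound 2 in one place: hydrogen in place of methyl on an aromatic carbon. Among the compounds with values here, the only measured step that bears on the aryl part of the benzyl group is a 2.2-fold lower number from compound 1 to compound 2 (0.34 log units; beyond the scatter), a modest change for a swap of two substituents on that ring. Compound 3 carries an unsubstituted benzyl group too, but it also differs from compound 2 on the shared core, so its much higher value cannot be assigned to either change alone. A modest weakening is therefore expected for compound 4, in the step of a 2.9-fold higher number from compound 2 to compound 4 (0.47 log units; beyond the scatter), with a wide range because compound 3 shows that an unsubstituted benzyl group can sit with a far higher number. Compound 4 is estimated at 5 nM, between 1.5 nM and 20 nM in this assay.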

Compound 4, half-maximal inhibitory concentration: 1.4 nM
Beside the measured number, compound 4's estimate is 3.6-fold (0.55 log units) above it; measured number outside the range, below it.
By their numbers in this assay, from the lowest: compounds 4 and 2 (each within the scatter of the next); then compound 1; then compound 3.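

In this assay, taking away the methyl leaves no difference that stands out from the scatter, a 1.2-fold lower number from compound 2 to compound 4 (0.08 log units; within the scatter), so the plain benzyl group serves as well as the 4-methylbenzyl group and this ring carbon needs no methyl to reach a low number. With a 2.6-fold lower number from compound 1 to compound 4 (0.42 log units; beyond the scatter) alongside it, the phenyl and 4-methylphenyl compounds sit together on the same side of compound 1. The methyl is not required for a number lower than that of compound 1. The pair that shares the unsubstituted benzyl group then isolates the change on the shared core, cyclopropyl in place of ethyl, as an 88-fold lower number from compound 3 to compound 4 (1.94 log units; beyond the scatter), so the high value of compound 3 cannot be laid to the missing methyl and this core change is much the larger of the steps shown.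

As far as these compounds go, whether a longer chain, an amine or a carboxylic acid at the ring carbon that held the methyl would keep the number this low remains open, as does how far other groups could stand in for cyclopropyl on the core. The material at hand offers no measured explanation for any of these steps.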